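Swapping a butylsulfanyl for a pentyl chain

The source may hold more compounds than are shown below. What is called first, only, known or untested is meant among the compounds shown, and "the series" means these compounds.

Three compounds have been measured in an assay on CHO cells for antagonist activity at transient receptor potential cation channel subfamily V member 1 (Homo sapiens), read by FLIPR; a lower number here means a stronger inhibitor, a higher number a weaker inhibitor:
Compound 1 `CC(C(=O)NCc1ccc(C(F)(F)F)cc1N1CCCCCC1)c1ccc(NS(C)(=O)=O)c(F)c1` gives 1.6 nM.
Compound 2 `CCC1CCN(c2cc(C(F)(F)F)ccc2CNC(=O)C(C)c2ccc(NS(C)(=O)=O)c(F)c2)CC1` gives 0.7 nM.
Compound 3 `CCCCSc1cc(C(F)(F)F)ccc1CNC(=O)C(C)c1ccc(NS(C)(=O)=O)c(F)c1` gives 1.9 nM.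

Going by the values given here, compound 3 shows the highest of the three numbers, though its gap to compound 1 lies within the scatter, as a 1.2-fold higher number from compound 1 to compound 3 (0.07 log units; within the scatter) shows; only the step of a 2.7-fold higher number from compound 2 to compound 3 (0.43 log units; beyond the scatter) is beyond it. Compound 4 `CCCCCc1cc(C(F)(F)F)ccc1CNC(=O)C(C)c1ccc(NS(C)(=O)=O)c(F)c1` differs from compound 3 at the same aromatic carbon: pentyl in place of butylsulfanyl on an aromatic carbon. Among the compounds with values here, no measured step replaces the butylsulfanyl with a pentyl, so the two steps at that carbon serve only as a rough guide to how much change this position tolerates; both were modest. No step beyond the scatter is therefore expected, and compound 4 is estimated at 1.8 nM (range 0.8 nM to 4 nM), meaning a step of a 1.1-fold lower number from compound 3 to compound 4 (0.02 log units; within the scatter).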

Compound 4, inhibition constant: 0.4 nM
For compound 4 the middle estimate is 4.5-fold (0.65 log units) above the measured one, outside the stated range (below it).
By their numbers in this assay, from the lowest: compounds 4 and 2 (each within the scatter of the next); then compounds 1 and 3 (each within the scatter of the next).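

At this aromatic carbon, a single atom counts: with the same number of heavy atoms and no ring on either side, pentyl in place of butylsulfanyl gives a clear change (a 4.8-fold lower number from compound 3 to compound 4 (0.68 log units; beyond the scatter)). A ring is also not needed for a low number, since the open pentyl chain cannot be told apart from 4-ethylpiperidin-1-yl (a 1.8-fold lower number from compound 2 to compound 4 (0.24 log units; within the scatter)) and clearly differs from azepan-1-yl (a 4.0-fold lower number from compound 1 to compound 4 (0.60 log units; beyond the scatter)).

Nothing available explains why the sulfur-to-carbon swap matters. From the compounds shown here alone, whether a hexyl or propyl chain, or a butoxy group with oxygen in place of sulfur, would behave like pentyl remains open.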